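Amide nitrogen substituent and adenosine receptor displacement

The source may hold more compounds than are shown below. What is called first, only, known or untested is meant among the compounds shown, and "the series" means these compounds.

Compound 3 `N#Cc1c(N)nc(SCC(=O)NCO)c(C#N)c1-c1ccc(OCC2CC2)cc1` stands lowest of the three numbers in an assay on CHO cells for displacement of a labelled ligand from adenosine receptor A1 (Homo sapiens), read by scintillation counting, with a stated time of 90 min, tested at 1 uM (on this read-out higher numbers stand for more inhibition at the one concentration tested (going by the name of the read-out) and lower numbers for less inhibition), at 10%. Compound 1 `N#Cc1c(N)nc(SCc2nc3ccccc3[nH]2)c(C#N)c1-c1ccc(OCC2CC2)cc1` gives 21% and compound 2 `N#Cc1c(N)nc(SCC(N)=O)c(C#N)c1-c1ccc(OCC2CC2)cc1` gives 31%; the steps of a number 11 percentage points lower from compound 1 to compound 3 (beyond the scatter) and a number 21 percentage points lower from compound 2 to compound 3 (beyond the scatter) lie beyond the scatter, whereas a number 10 percentage points higher from compound 1 to compound 2 (within the scatter) does not. Compound 4 `CNC(=O)CSc1nc(N)c(C#N)c(-c2ccc(OCC3CC3)cc2)c1C#N` differs from compound 3 in one place: hydrogen in place of hydroxy on a saturated chain carbon bound to an amide-type nitrogen. The step that bears on this is a number 21 percentage points lower from compound 2 to compound 3 (beyond the scatter), which introduced the hydroxymethyl; taking the hydroxy away undoes part of that change, so a rise beyond the scatter in this assay is expected, though not necessarily all the way back. Compound 4 is therefore estimated at 22% with a range of 8% to 36%, an expected step of a number 12 percentage points higher from compound 3 to compound 4 (beyond the scatter).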

Compound 4, a percentage reported as inhibition, at one concentration (the size of the read-out at that concentration, not a potency): 14%
For compound 4 the middle estimate is 8 percentage points above the measured one; measured number inside the range.
By their numbers in this assay, from the lowest: compounds 3, 4, 1 and 2 (each within the scatter of the next, the first and the last beyond it).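

Hydroxy and hydrogen on the saturated chain carbon bound to the amide-type nitrogen cannot be told apart in this assay (a number 4 percentage points higher from compound 3 to compound 4 (within the scatter)), so the hydroxy itself carries no readable effect here. Methyl on the amide-type nitrogen alone is enough for a drop beyond the scatter (a number 17 percentage points lower from compound 2 to compound 4 (beyond the scatter)), and compounds 3 and 4 read alike on that nitrogen. Methylcarbamoyl and 1H-benzimidazol-2-yl stay within the scatter (a number 7 percentage points lower from compound 1 to compound 4 (within the scatter)).

No evidence accounts for the lower numbers with a substituted amide nitrogen. On these data alone, whether a longer chain on that nitrogen, or a carboxylic acid in place of the carbamoyl, would lower the number further remains open.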